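Extending the methyl of compound 2 to propyl

A few compounds are considered here, and "the series" means these few. Any claim that something is new, unique, unknown or untested is made for them only; others in the source may bear on it.

Compound 2 `Cc1cc(-c2ccc(F)cc2)nn1Cc1ccc(C(=O)NO)cc1` gives the lowest number among the three measured compounds in an assay on cells for inhibition of protein deacetylase HDAC6 (Homo sapiens), read by fluorescence, with stated times of 15 min and 60 min (on this read-out lower numbers stand for stronger inhibition and higher numbers for weaker inhibition), at 8 nM. Its isomer compound 3 `Cc1cc(-c2ccc(F)cc2)n(Cc2ccc(C(=O)NO)cc2)n1` gives 20 nM in this assay, and compound 1 `O=C(NO)c1ccc(Cn2nc(-c3ccc(F)cc3)cc2Cc2ccccc2)cc1` gives 326 nM. Compound 4 `CCCc1cc(-c2ccc(F)cc2)nn1Cc1ccc(C(=O)NO)cc1` differs from compound 2 by ethyl in place of hydrogen on a saturated chain carbon bound to an aromatic carbon. Within the data shown here, only one measured step touches that carbon: a 41-fold lower number from compound 1 to compound 2 (1.61 log units; beyond the scatter), where the loss of phenyl brought a large fall in the number. Because a 41-fold lower number from compound 1 to compound 2 (1.61 log units; beyond the scatter) went that way, compound 4, which adds a group at the same carbon, is expected to give a somewhat higher number than compound 2, beyond the scatter but far smaller than that step. The expected step is a 2.5-fold higher number from compound 2 to compound 4 (0.40 log units; beyond the scatter). For compound 4 the estimate in this assay is 20 nM, with a range from 6 nM to 70 nM.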

Compound 4, half-maximal inhibitory concentration: 107 nM
Compound 4: middle estimate off by 5.4-fold (0.73 log units), on the low side; the whole stated range lies below it.
By their numbers in this assay, from the lowest: compound 2; then compound 3; then compound 4; then compound 1.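

In this assay this carbon proves sensitive even to a small open chain: ethyl in place of hydrogen gives a 13-fold higher number from compound 2 to compound 4 (1.13 log units; beyond the scatter) and no ring is needed for a large rise in the number. Phenyl at the same carbon still goes further, as ethyl in place of phenyl gives only a 3.0-fold lower number from compound 1 to compound 4 (0.48 log units; beyond the scatter) in the other direction. Nothing at hand explains this order. As far as these compounds go, whether the rise grows steadily with chain length stays open, as does how an amine or a hydroxyl at the end of the propyl chain would read.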